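A few compounds are considered here, and "the series" means these few. Any claim that something is new, unique, unknown or untested is made for them only; others in the source may bear on it.

Of the compounds shown here, three sharing one core have been measured in a physicochemical assay for solubility, read by HPLC, at pH 6.5 (on this read-out higher numbers stand for higher solubility and lower numbers for lower solubility), so far. Compound 1 `OC1CC2(CCN(CCC3CCCCC3)CC2)Oc2c1ccc1ccccc21` gives 20000 nM on this read-out. Compound 2 `OC1CC2(CCNCC2)Oc2c1ccc1ccccc21` reports only a limit of <= 10000 nM and no exact number. Compound 3 `CCN1CCC2(CC1)CC(O)c1ccc3ccccc3c1O2` gives 20000 nM and stands level with compound 1 at the digits shown.

Compound 4 `CCN1CCC2(CCc3ccc4ccccc4c3O2)CC1` keeps the ethyl group of compound 3 and differs elsewhere: hydrogen in place of hydroxy on a saturated ring carbon. For the measured compounds named here, none of the measured steps touches that carbon. All three change only the group on the amine nitrogen in a ring: an at least 2.0-fold lower number from compound 1 to compound 2 (0.30 log units; that floor lies within the scatter) and no change at the digits printed from compound 1 to compound 3 (within the scatter) and an at least 2.0-fold higher number from compound 2 to compound 3 (0.30 log units; that floor lies within the scatter) are the whole record. They offer only a loose guide to size, so the expectation stays close to compound 3 at 20000 nM and leans slightly lower. The expected move is a 1.3-fold lower number from compound 3 to compound 4 (0.10 log units; within the scatter) and is not expected to exceed the scatter. The estimate for compound 4 is 16000 nM with an expected range from 8000 nM to 30000 nM in this assay.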

Compound 4, solubility: <= 10000 nM
Compound 4 gave a limit, no number; the forecaster's own chance of this, stated with the estimate: 30%; at least 1.6-fold (0.20 log units) between middle value and limit.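

For the compounds shown here, until now, every measured step changed only the group on the amine nitrogen in a ring, so this is the first look at the saturated ring carbon, three ring bonds from the ring oxygen. In this assay, hydrogen in place of hydroxy at this carbon gives an at least 2.0-fold lower number from compound 3 to compound 4 (0.30 log units; that floor lies within the scatter), so the step has only a floor and no exact size. The reading for compound 4 is a limit rather than a number, and it is not alone in this: the limit of <= 10000 nM in this assay, at which 2 of the 4 values shown sit.

As far as these compounds go, whether the true step at this carbon goes beyond the usual scatter therefore remains open. Also open is what an amine or a carboxylic acid on this same carbon would do to the reading, since hydroxy and hydrogen are the only groups shown there.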